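This account rests on a few compounds, and the source may have more. Where it says the series, first, only, none or still open, it means among the compounds named here.

In an assay for binding affinity to dual specificity mitogen-activated protein kinase kinase 4 (Homo sapiens), read by KINOMEscan, tested at 100 nM (on this read-out higher numbers stand for a weaker effect at the one concentration tested and lower numbers for a stronger effect), compound 1 `CCCS(=O)(=O)Nc1ccc(F)c(C(=O)c2n[nH]c3ncc(-c4ccc(F)cc4)cc23)c1F` gives 2.1%, a strong effect at the single concentration tested. Compound 2 `CCCS(=O)(=O)Nc1ccc(F)c(C(=O)c2n[nH]c3ncc(-c4cccc(N(C)C)c4)cc23)c1F` shares the whole of this core and differs only in the aromatic group attached to it; in this assay compound 2 gives 26%. Among the measured compounds shown here, of the two numbers known, compound 2 stands highest, the weaker of the two: the step of a number 23.9 percentage points higher from compound 1 to compound 2 (beyond the scatter) lies beyond the scatter, though it is modest in size.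

Compound 3 `CCCS(=O)(=O)Nc1ccc(F)c(C(=O)c2n[nH]c3ncc(-c4ccc(N(C)C)cc4)cc23)c1F` is made from compound 2 by one rearrangement, (4-(dimethylamino)phenyl in place of 3-(dimethylamino)phenyl on an aromatic carbon). For the measured compounds named here, only one measured step touches this part of the molecule, the one from compound 1 to compound 2, and it exchanged a different group rather than moving the same group to another carbon of the same ring, so it gives only a rough guide: a change at this place can shift the read-out by a modest amount. Going by the values given here, no measured pair shows a pure shift of position, so the direction of the expected step in this assay is uncertain and it is expected to stay within the scatter, a number 8 percentage points lower from compound 2 to compound 3 (within the scatter). Compound 3 is therefore estimated at 18%, with a range from 3% to 45%.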

Compound 3, a percentage reported as activity, at one concentration (the size of the read-out at that concentration, not a potency): 2.5%
Compound 3: middle estimate off by 15.5 percentage points, on the high side; the whole stated range lies above it.
By their numbers in this assay, from the lowest: compounds 1 and 3 (each within the scatter of the next); then compound 2.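

In this assay, moving the dimethylamino group on the phenyl ring is enough on its own to change the read-out: with the same atoms joined differently, the result is a number 23.5 percentage points lower from compound 2 to compound 3 (beyond the scatter), so 3-(dimethylamino)phenyl and 4-(dimethylamino)phenyl cannot be treated as equivalent at this position. The first step exchanged both the substituent and its place on the ring, whereas the new comparison separates the two: a number 0.4 percentage points higher from compound 1 to compound 3 (within the scatter) shows that dimethylamino in place of fluoro leaves the two compounds indistinguishable, so among these three compounds the weaker effect goes with the 3-(dimethylamino)phenyl arrangement, not with the dimethylamino group as such. The data at hand offer no explanation for why this placement matters.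

Going by these compounds, it remains open whether the same difference between the two arrangements would appear with another substituent, for example when comparing 3-fluorophenyl with the 4-fluorophenyl of compound 1, or 3-methoxyphenyl with 4-methoxyphenyl. Larger amines such as a morpholine or a piperazine on the phenyl ring, or a carboxylic acid there, also leave open how much variety this position accepts in this assay.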